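Triazolylthioacetanilides: aryl amide change from compound 3 to 4

The source may report more compounds than this note shows. Statements on the series, on what has been measured and on what is new or still open speak of the compounds shown alone.

Measured in a functional assay on CHO cells for antagonist activity at Orexin/Hypocretin receptor type 1 (Homo sapiens), read by FLIPR and calcium flux; on this read-out higher numbers stand for weaker inhibition and lower numbers for stronger inhibition:
compound 1 `Cc1cccc(NC(=O)CSc2nnc(-c3ccoc3C)n2Cc2ccco2)c1C`: > 15800 nM (a limit of the assay, not a number)
compound 2 `Cc1occc1-c1nnc(SCC(=O)Nc2ccc(F)c(Cl)c2)n1Cc1ccco1`: 1000 nM
compound 3 `Cc1cccc(NC(=O)CSc2nnc(-c3ccoc3C)n2Cc2ccco2)c1`: 2510 nM

Among the two numbers, compound 3 stands highest; compound 2 sits a 2.5-fold higher number from compound 2 to compound 3 (0.40 log units; beyond the scatter) away from it. Compound 1 reaches only (the limit of > 15800 nM in this assay, at which 1 of the 3 values shown sits). Moving from compound 1 gave an at least 6.2-fold lower number from compound 1 to compound 3 (0.79 log units; beyond the scatter) and an at least 15-fold lower number from compound 1 to compound 2 (1.19 log units; beyond the scatter), so the aryl group on the amide nitrogen clearly moves this assay, with the 2,3-dimethylphenyl variant the weakest shown.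

Compound 4 `COc1ccc(NC(=O)CSc2nnc(-c3ccoc3C)n2Cc2ccco2)cc1` is not yet measured. It differs from compound 3 as follows: 4-methoxyphenyl in place of 3-methylphenyl on an amide-type nitrogen. Among the measured compounds shown here, no measured step exchanges a methyl for a methoxy, or shifts a substituent to the 4-position, so the direction rests on analogy only: the aryl changes seen so far range from modest to large, and a 4-methoxyphenyl is a change of similar scope. A step near the scatter, leaning toward a somewhat higher number, is expected, a 1.6-fold higher number from compound 3 to compound 4 (0.20 log units; within the scatter). The estimate for compound 4 in this assay is 4000 nM, with a range from 1500 nM to 12000 nM.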

Compound 4, inhibition constant: > 15800 nM
Compound 4: only a limit was reported; the forecaster's own chance of this, stated with the estimate: 20%; middle value at least 3.9-fold (0.59 log units) away from the limit.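

In this assay, among the compounds shown here, the aryl group on the amide nitrogen proves less forgiving than the earlier compounds showed: 4-methoxyphenyl gives an at least 6.2-fold higher number from compound 3 to compound 4 (0.79 log units; beyond the scatter) and an at least 15-fold higher number from compound 2 to compound 4 (1.19 log units; beyond the scatter). Compound 4 gives > 15800 nM, which is a limit of the assay and not a number, so both steps give only the smallest possible size of the change. Falling out of the readable range is thus not confined to the 2,3-dimethylphenyl of compound 1, though the step between these two compounds cannot be read: the limit of > 15800 nM in this assay, at which 2 of the 4 values shown sit.

As far as these compounds go, whether the methoxy group itself or its 4-position governs this change stays open; a 3-methoxyphenyl and a 4-methylphenyl would separate the two. Also open, from the compounds shown here alone, is how this aryl group responds to an amine or a carboxylic acid.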